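Series notes: benzyl extension on the ring amide nitrogen

A few compounds are considered here, and "the series" means these few. Any claim that something is new, unique, unknown or untested is made for them only; others in the source may bear on it.

Compound 3 `CN1C(=O)C(O)(Cc2nnn[nH]2)c2cc(Br)ccc21` is the bromo member of the shared core with methyl on the ring amide nitrogen. In a functional assay on PC-3 cells (Homo sapiens) for antiproliferative activity, read by MTT assay, with a stated time of 48 h (on this read-out lower numbers stand for stronger inhibition and higher numbers for weaker inhibition), compound 3 gives only a limit, > 100000 nM. Compound 2 `CN1C(=O)C(O)(Cc2nnn[nH]2)c2cc(Cl)ccc21` carries chloro in the same place; in this assay compound 2 likewise gives only a limit, > 100000 nM. The step that the two limits leave unreadable from compound 2 to compound 3 is therefore not readable. Compound 1 `O=C1N(Cc2ccc(Br)cc2)c2ccc(F)cc2C1(O)Cc1nnn[nH]1`, which bears fluoro on the core and 4-bromobenzyl on the ring amide nitrogen, gives only a limit as well in this assay, > 100000 nM. Among the measured compounds shown here, every measured value sits at the limit of > 100000 nM in this assay, at which 3 of the 3 values shown sit, so no step within the set has a readable size.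

Compound 4 `O=C1N(Cc2ccc(Br)cc2)c2ccc(Br)cc2C1(O)Cc1nnn[nH]1` arises from compound 3 by 4-bromophenyl in place of hydrogen on a saturated chain carbon bound to an amide-type nitrogen in a ring. For the measured compounds named here, no measured pair shows this change with a number on either side; compound 1 carries the same 4-bromobenzyl group and gives only a limit. Because every measured member sits at the limit of > 100000 nM in this assay, at which 3 of the 3 values shown sit, the expectation for compound 4 is no readable movement in this assay. Compound 4 is estimated to remain at the limit, with a step that the limit leaves unreadable from compound 3 to compound 4 expected to be unreadable. Compound 4 is expected at 200000 nM, within 50000 nM to 1000000 nM.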

Compound 4, half-maximal inhibitory concentration: > 100000 nM
Compound 4 ended at the assay's limit (the forecaster's own chance of this, stated with the estimate: 85%); the middle value lies beyond the limit too.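

In this assay no new step can be read for compound 4 against compound 3 or compound 1, as all of these values are limits: the limit of > 100000 nM in this assay, at which 4 of the 4 values shown sit.

The compounds shown leave open whether methyl to 4-bromobenzyl, or bromo in place of fluoro, changes antiproliferative activity at all, since none gives a readable number.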